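This account rests on a few compounds, and the source may have more. Where it says the series, first, only, none or still open, it means among the compounds named here.

Compound 1, `CC(C)N(Cc1cccc(OCCCCCC(=O)O)c1)C(=O)c1ccc(-c2cccc(O)c2)cc1`: > 26000 nM
Compound 2, `CCOC(=O)CCCCCOc1cccc(CN(C(=O)c2ccc(-c3cccc(N(C)C)c3)cc2)C(C)C)c1`: > 26000 nM

Both compounds were tested in an ADME assay on Raji cells (Homo sapiens) for cytotoxicity, read by CellTiter-Glo and resazurin assay, with a stated time of 72 h; a higher number here means that more compound is needed for the effect, a lower number that less compound is needed. Compound 1 gave only a limit there, > 26000 nM, not a number. Compound 2 likewise gave only a limit, > 26000 nM, so no exact number is known for it either. Going by the values given here, this is the limit of > 26000 nM in this assay, at which 2 of the 2 values shown sit, and with both values sitting at that limit, no step between the two compounds can be counted.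

Compound 3, `CCOC(=O)CCCCCOc1cccc(CN(C(=O)c2ccc(-c3ccc4cc[nH]c4c3)cc2)C(C)C)c1`, has not yet been measured in this assay. It differs from compound 2 in one place: 1H-indol-6-yl in place of 3-(dimethylamino)phenyl on an aromatic carbon. Among the compounds with values here, no measured step between compounds is available to suggest a size or direction for this change. The expected step in this assay is therefore none beyond the scatter, a step that the limit leaves unreadable from compound 2 to compound 3. Compound 3 is expected to give about 40000 nM, in a range from 15000 nM to 150000 nM, and quite possibly only a limit once more.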

Compound 3, half-maximal effective concentration: > 26000 nM
Compound 3 gave a limit, no number; the forecaster's own chance of this, stated with the estimate: 80%; the middle value does not contradict the limit.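

Going by these compounds alone, compound 2 and compound 3 each gave only a limit in this assay, so no step between them can be read: the limit of > 26000 nM in this assay, at which 3 of the 3 values shown sit.

The compounds shown leave open how much of each is needed for the effect in this assay and whether 1H-indol-6-yl in place of 3-(dimethylamino)phenyl changes that amount at all.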